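Sulfamoyl carbamates: from hexyl to benzimidazolyl on the sulfonamide nitrogen

This account rests on a few compounds, and the source may have more. Where it says the series, first, only, none or still open, it means among the compounds named here.

Compound 1 `CC(C)c1cccc(C(C)C)c1OC(=O)NS(=O)(=O)N1CCOCC1`: > 100000 nM
Compound 2 `CCCCCCNS(=O)(=O)NC(=O)Oc1c(C(C)C)cccc1C(C)C`: 21000 nM

The two measured compounds share a carbamate core and differ only at the sulfonyl sulfur. In an assay on liver for inhibition of sterol O-acyltransferase 1 (Rattus norvegicus), using microsomes (a higher number here means a weaker inhibitor, a lower number a stronger inhibitor), compound 1 gives > 100000 nM, which is a limit of the assay and not a number. Within the data shown here, compound 2, with hexylamino on the sulfonyl sulfur, gives 21000 nM and is thus the only compound with a numerical value here; the step of an at least 4.7-fold lower number from compound 1 to compound 2 (0.67 log units; beyond the scatter) rests on that limit, as the evidence the limit of > 100000 nM in this assay, at which 1 of the 2 values shown sits, shows.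

Compound 3 `CC(C)c1cccc(C(C)C)c1OC(=O)NS(=O)(=O)Nc1nc2ccccc2[nH]1` has not been measured. It differs from compound 2 by 1H-benzimidazol-2-yl in place of hexyl on a sulfonamide nitrogen. Among the measured compounds shown here, no measured step bears directly on this exchange, since the only step alters the sulfonyl substituent rather than the group on the sulfonamide nitrogen. Compound 3 is therefore expected to stay near compound 2, with a step of a 1.2-fold higher number from compound 2 to compound 3 (0.08 log units; within the scatter) in this assay, giving an estimate of 25000 nM, ranging from 4000 nM to 150000 nM.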

Compound 3, half-maximal inhibitory concentration: 52000 nM
Compound 3: the middle estimate sits 2.1-fold (0.32 log units) below what was measured, within the range that was stated.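

The earlier step exchanged the whole group on the sulfonyl sulfur, whereas here the sulfonamide nitrogen stays and only its substituent changes. In this assay, 1H-benzimidazol-2-yl in place of hexyl gives a 2.5-fold higher number from compound 2 to compound 3 (0.39 log units; beyond the scatter), so this position accepts two aromatic rings in place of an open chain at the cost of only a modest step. Nothing measured here accounts for that step.

The compounds shown leave open how a longer alkyl chain, a phenyl ring or a pyridin-2-yl group on the sulfonamide nitrogen would read, so the step cannot yet be tied to the ring nitrogens or to the rings themselves. They also leave open whether an amide in place of the carbamate would move the numbers in the same direction.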